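Changing the Chain End of Compound 1

The source may report more compounds than this note shows. Statements on the series, on what has been measured and on what is new or still open speak of the compounds shown alone.

Among the measured compounds shown here, in a functional assay on KB cells (Homo sapiens) for antiproliferative activity, read by MTT assay, with a stated time of 48 h (a higher number here means a weaker inhibitor, a lower number a stronger inhibitor), compound 1 `Cn1cc(C2=C(c3nn(CCCN4CCCCC4)c4ncccc34)C(=O)N(c3ccccc3)C2=O)c2ccccc21` gives 5600 nM, the lowest of the two actual numbers so far. Compound 3 `Cn1cc(C2=C(c3nn(CCCN4CCCCC4)c4ncccc34)C(=O)N(c3cccc4ccccc34)C2=O)c2ccccc21` is the nearest, at 13400 nM. Compound 2 `Cn1cc(C2=C(c3nn(CCCN4CCCCC4)c4ncccc34)C(=O)N(c3ccc(Cl)cc3)C2=O)c2ccccc21` reads > 100000 nM, which is a limit of the assay and not a number.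

Compound 4 `Cn1cc(C2=C(c3nn(CCCCn4ccnc4)c4ncccc34)C(=O)N(c3ccccc3)C2=O)c2ccccc21` keeps the core of compound 1 but alters the end of its chain: (1H-imidazol-1-yl)methyl in place of piperidin-1-yl on a saturated chain carbon, three bonds along the chain from an aromatic nitrogen. Read along the whole chain, 3-(piperidin-1-yl)propyl gives way to 4-(1H-imidazol-1-yl)butyl. For the measured compounds named here, no measured step touches this chain, so the evidence is only indirect. Both steps available from compound 1 change the group on the amide-type nitrogen in a ring instead: an at least 17-fold higher number from compound 1 to compound 2 (1.25 log units; beyond the scatter) and a 2.4-fold higher number from compound 1 to compound 3 (0.38 log units; beyond the scatter). Each raises the number, one by a large step and one by a modest step. With so little to go on, a modest rise is expected, though the direction is uncertain. The expected change is a 1.6-fold higher number from compound 1 to compound 4 (0.21 log units; within the scatter). Compound 4 is estimated at 9000 nM, with an expected range of 2500 nM to 35000 nM.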

Compound 4, half-maximal inhibitory concentration: 47300 nM
Estimate against measurement, compound 4: 5.3-fold (0.72 log units) below; the whole stated range lies below it.
By their numbers in this assay, from the lowest: compound 1; then compound 3; then compound 4. At a limit, above all of these: compound 2.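

Every earlier step changed the group on the amide-type nitrogen in a ring, so the chain end had not yet been tested. In this assay, going from 3-(piperidin-1-yl)propyl to 4-(1H-imidazol-1-yl)butyl gives an 8.4-fold higher number from compound 1 to compound 4 (0.93 log units; beyond the scatter), which shows that the end of this chain also shifts the number, even with that nitrogen's phenyl group unchanged. Nothing measured here accounts for the rise.

This single change replaces a six-membered non-aromatic ring with a five-membered aromatic ring and also turns a propyl chain into a butyl chain, so the compounds shown cannot separate the two. Still open, from the compounds shown here alone, are 3-(1H-imidazol-1-yl)propyl, which would keep the chain of compound 1 while changing its ring, and 4-(piperidin-1-yl)butyl, which would keep the ring while changing the chain.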